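The source may hold more compounds than are shown below. What is called first, only, known or untested is meant among the compounds shown, and "the series" means these compounds.

Compound 1 `COc1cc(N(Cc2nc3ccccc3[nH]2)S(=O)(=O)c2ccccc2)cc(OC)c1OC`: 27300 nM. Compound 2 `COc1cc(N(Cc2nc3ccccc3[nH]2)S(=O)(=O)c2ccc(F)cc2)cc(OC)c1OC`: 9380 nM.

Going by the values given here, in a functional assay on MCF7 cells (Homo sapiens) for inhibition, read by MTT assay, with a stated time of 48 h (on this read-out lower numbers stand for stronger inhibition and higher numbers for weaker inhibition), compound 2 stands as the lowest of the two numbers; its only neighbour is compound 1, and the step between them, a 2.9-fold lower number from compound 1 to compound 2 (0.46 log units; beyond the scatter), is the one measured step so far. Compound 3 `COc1cc(N(Cc2nc3ccccc3[nH]2)C(=O)c2ccccc2)cc(OC)c1OC` has not yet been measured. It differs from compound 2 in one place: benzoyl in place of (4-fluorophenyl)sulfonyl on a nitrogen on an aromatic ring. This change does two things at once. It removes the fluorine by which compound 1 and compound 2 differ, and it replaces the sulfonyl link with a carbonyl link. Only the first part has a measured counterpart, the step from compound 1 to compound 2, which would be expected to run backwards here; the second part has none. Compound 3 is therefore expected to give a higher number than compound 2, with the step of a 2.7-fold higher number from compound 2 to compound 3 (0.43 log units; beyond the scatter), and its estimated value is 25000 nM, in a range from 8000 nM to 80000 nM.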

Compound 3, half-maximal inhibitory concentration: > 50000 nM
Compound 3: a limit, no number (the forecaster's own chance of this, stated with the estimate: 15%); middle value at least 2.0-fold (0.30 log units) from the limit.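

In this assay compound 3 gives > 50000 nM, which is a limit of the assay and not a number: the limit of > 50000 nM in this assay, at which 1 of the 3 values shown sits.

Changing the group on this nitrogen matters, since removing the fluorine and replacing the sulfonyl link with a carbonyl link together give an at least 5.3-fold higher number from compound 2 to compound 3 (0.72 log units; beyond the scatter). With no fluorine on either side, benzoyl in place of phenylsulfonyl gives an at least 1.8-fold higher number from compound 1 to compound 3 (0.26 log units; that floor lies within the scatter), so this comparison alone does not establish that the carbonyl link performs worse than the sulfonyl link.

The compounds shown leave open how much of the weaker result belongs to losing the fluorine and how much to changing the link, a question that a 4-fluorobenzoyl group on this nitrogen would help to separate. They also leave open whether a benzyl group, with neither a sulfonyl nor a carbonyl link, would retain any inhibition.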